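Inverting Both Ring Stereocentres of Compound 2

The source may hold more compounds than are shown below. What is called first, only, known or untested is meant among the compounds shown, and "the series" means these compounds.

Of the compounds shown here, two have been measured in a functional assay on FL5.12 cells (Mus musculus), read by flow cytometry, with a stated time of 3 h, tested at 10 uM (a higher number here means a stronger effect of the compound at the concentration tested, a lower number a weaker effect), so far. Compound 1 `CCCCCCCCc1ccc(C(C[C@@H]2CCCN2)OC)cc1` gives 58%. Compound 2 `CCCCCCCCc1ccc(CC(O)[C@@H]2C[C@@H](O)CN2)cc1` gives 62%, and compound 1 sits within the usual scatter of that value, so the two are not separated. Compound 3 `CCCCCCCCc1ccc(CC(O)[C@H]2C[C@H](O)CN2)cc1` is unmeasured; it differs from compound 2 as follows: the two compounds have the same atoms and bonds; at least one stereo element is drawn with a configuration in one of them and without one in the other: 2 of 3 stereo elements differ; a stereocentre at a saturated ring carbon is drawn S in compound 2 and R in compound 3; a stereocentre at a saturated ring carbon is drawn R in compound 2 and S in compound 3. Going by the values given here, no step between measured compounds shows how such an inversion acts here, so a step in either direction is possible and none beyond the scatter is assumed. Compound 3 is therefore expected near 52%, from 22% to 80%, which is estimated as a step of a number 10 percentage points lower from compound 2 to compound 3 (within the scatter) in this assay.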

Compound 3, a percentage reported as activity, at one concentration (the size of the read-out at that concentration, not a potency): 62%
Compound 3: middle estimate off by 10 percentage points, on the low side; low and high end bracket the measured number.
By their numbers in this assay, from the lowest: compounds 1, 2 and 3 (each within the scatter of the next).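

In this assay, going by these compounds alone, inverting both stereocentres at saturated ring carbons gives no change at the digits printed from compound 2 to compound 3 (within the scatter), the first direct reading of such a change. At this single concentration, the read-out therefore does not separate the two drawn arrangements at these ring carbons. One point limits how far this comparison can be taken: the fact that one of compounds 2 and 3 is drawn with a defined configuration and the other without, at the place where they differ

The compounds shown leave open whether inverting only one of these ring stereocentres would give the same result. They also leave open how an amine or a carboxylic acid in place of the ring hydroxyl would read.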